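The source may hold more compounds than are shown below. What is called first, only, known or untested is meant among the compounds shown, and "the series" means these compounds.

Compound 1 `COc1cc(F)ccc1-c1ccnc2[nH]c(C3CCN(CC(=O)N(C)C)CC3)cc12` and compound 2 `CN(C)C(=O)CN1CCC(c2cc3c(-c4ccc(=O)n(C5CCOCC5)c4)ccnc3[nH]2)CC1` share a core and the same side chain on it. In an ADME assay on microsomes from liver (Homo sapiens) for metabolic stability (a lower number here means slower removal, a higher number faster removal of the compound), compound 1 gives 14 uL/min, the higher of the two numbers recorded so far. In this assay compound 2 gives 8.2 uL/min, a gap from compound 1 that lies within the usual scatter, so no order between the two can be claimed. Compound 3 `COc1cc(=O)n(C)cc1-c1ccnc2[nH]c(C3CCN(CC(=O)N(C)C)CC3)cc12` has not yet been measured. It differs from compound 1 in one place: a group of 10 heavy atoms (7 carbon, 1 nitrogen, 2 oxygen; one six-membered aromatic ring with 1 hetero atom) in place of a group of 9 heavy atoms (7 carbon, 1 oxygen, 1 fluorine; one six-membered aromatic ring of carbon only), on an aromatic carbon. For the measured compounds named here, no measured pair on hand tracks this change directly, so any expectation rests on the two numbers above. The step from compound 1 to compound 3 in this assay is expected to be small and downward, quite possibly not beyond the scatter, estimated as a 1.5-fold lower number from compound 1 to compound 3 (0.17 log units; within the scatter). For compound 3 the expected value in this assay is 9.5 uL/min, with a range from 4.5 uL/min to 20 uL/min.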

Compound 3, intrinsic clearance in a liver preparation (reported as CLH), per the amount of preparation that the assay uses: < 3 uL/min
Compound 3 ended at the assay's limit; the forecaster's own chance of this, stated with the estimate: 10%; middle value at least 3.1-fold (0.50 log units) away from the limit.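

In this assay compound 3 gives < 3 uL/min, which is a limit of the assay and not a number. Replacing 4-fluoro-2-methoxyphenyl with the six-membered aromatic ring with 1 hetero atom, on the aromatic carbon opposite the ring nitrogen, gives an at least 4.6-fold lower number from compound 1 to compound 3 (0.66 log units; beyond the scatter), the first single change shown in this series that goes beyond the scatter. Only a minimum can be read for this step, and its full size stays unknown, because compound 3 sits at the limit: the limit of < 3 uL/min in this assay, at which 1 of the 3 values shown sits.

Which part of the change carries the step remains open, as the fluorine, the ring nitrogen and the carbonyl all change together between these two compounds. Going by these compounds, how an amine or a carboxylic acid on this aromatic carbon would read in this assay also remains open.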